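Lengthening the Hydroxamic Acid Chain: Compound 3 to Compound 4

The compounds below may be only part of what the source reports. "The series", "measured", "known", "first", "only" and "open" are said of these compounds alone.

Three related compounds have been measured in an assay on isolated protein for inhibition of protein deacetylase HDAC6 (Homo sapiens), with a stated time of 60 min, tested at 10 nM; on this read-out lower numbers stand for less inhibition and higher numbers for more inhibition at the one concentration tested (going by the name of the read-out). Compound 1 `O=C(CCCCCCn1cc(Nc2ncc3ccn(Cc4ccc(F)cc4)c3n2)cn1)NO` gives 62%. Compound 2 `O=C(CCCCCCn1cc(Nc2ncc3ccn(Cc4ccc(Cl)cc4)c3n2)cn1)NO` gives 39%. Compound 3 `Cc1ccc(Cn2ccc3cnc(Nc4cnn(CCCCCC(=O)NO)c4)nc32)cc1` gives 34%, the lowest of the three numbers; its gap to compound 2 lies within the scatter, while the gap to compound 1 lies beyond it.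

Within the data shown here, the only measured step between compounds that differ in one place is a number 23 percentage points lower from compound 1 to compound 2 (beyond the scatter). That step concerns the halogen on the benzyl ring, not the chain that carries the hydroxycarbamoyl group, so it does not speak directly to the change at hand.

Compound 4 `Cc1ccc(Cn2ccc3cnc(Nc4cnn(CCCCCCC(=O)NO)c4)nc32)cc1` differs from compound 3 by (hydroxycarbamoyl)methyl in place of hydroxycarbamoyl on a saturated chain carbon, five bonds along the chain from an aromatic nitrogen. In effect, the chain between the aromatic nitrogen and the hydroxycarbamoyl end becomes one unit longer, while the hydroxycarbamoyl end itself, with its two hydrogen-bond donors and two acceptors, stays the same.

Among the measured compounds shown here, no measured pair shows what a longer chain of this kind does in this assay, so there is no basis for expecting a step beyond the scatter in either direction. The expected step from compound 3 is therefore a number 1 percentage points higher from compound 3 to compound 4 (within the scatter), and compound 4 is estimated at 35%, with a range from 15% to 55%.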

Compound 4, a percentage reported as inhibition, at one concentration (the size of the read-out at that concentration, not a potency): 38%
Estimate against measurement, compound 4: 3 percentage points below; measured number inside the range.
By their numbers in this assay, from the lowest: compounds 3, 4 and 2 (each within the scatter of the next); then compound 1.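

In this assay, putting (hydroxycarbamoyl)methyl in place of hydroxycarbamoyl on this saturated chain carbon gives a number 4 percentage points higher from compound 3 to compound 4 (within the scatter), so with methyl on the aromatic carbon, this lengthening of the chain produces no readable change. Compound 4 also shares its chain with the two halogen compounds, which gives a set of three that differ in one place only, the group on that aromatic carbon: methyl in place of chloro gives a number 1 percentage points lower from compound 2 to compound 4 (within the scatter), while methyl in place of fluoro gives a number 24 percentage points lower from compound 1 to compound 4 (beyond the scatter), so methyl and chloro cannot be told apart here and fluoro stands apart from both. Nothing at hand explains why fluoro differs from the other two groups.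

The compounds shown leave open whether the same chain change would also make no readable difference with fluoro on the aromatic carbon, where the number at this chain length is higher. They also leave open how a still longer chain, or a methoxy or trifluoromethyl group on that aromatic carbon, would read in this assay.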